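Chain growth on a shared core and its effect

A few compounds are considered here, and "the series" means these few. Any claim that something is new, unique, unknown or untested is made for them only; others in the source may bear on it.

Compound 1 `CC(C)=NNc1nc(-c2cccc([N+](=O)[O-])c2)cs1` is the smallest of three measured compounds. In a functional assay, with a stated time of 30 min (a lower number here means a stronger inhibitor, a higher number a weaker inhibitor), compound 1 gives 1160000 nM. Compound 2 `CCC/C(C)=N\Nc1nc(-c2cccc([N+](=O)[O-])c2)cs1` carries ethyl in place of hydrogen on a saturated chain carbon bound to a carbon with a double bond to nitrogen; in this assay compound 2 gives 1200000 nM, the step being a 1.0-fold higher number from compound 1 to compound 2 (0.01 log units; within the scatter). Compound 3 `CCC/C(CC)=N\Nc1nc(-c2cccc([N+](=O)[O-])c2)cs1` differs from compound 1 by a group of 7 heavy atoms (6 carbon, 1 nitrogen; no ring) in place of a group of 4 heavy atoms (3 carbon, 1 nitrogen; no ring), on a nitrogen on an aromatic ring, and from compound 2 by methyl in place of hydrogen on a saturated chain carbon bound to a carbon with a double bond to nitrogen. In this assay compound 3 gives 1230000 nM; the steps are a 1.1-fold higher number from compound 1 to compound 3 (0.03 log units; within the scatter) and a 1.0-fold higher number from compound 2 to compound 3 (0.01 log units; within the scatter). Compound 4 `CCCCC/C(CC)=N\Nc1nc(-c2cccc([N+](=O)[O-])c2)cs1`, not yet measured, shows (ethyl in place of hydrogen on a saturated chain carbon, three bonds along the chain from a carbon with a double bond to nitrogen). This is the same kind of change as that from compound 1 to compound 2, where the ethyl entered on a saturated chain carbon bound to a carbon with a double bond to nitrogen, whereas here it enters on a saturated chain carbon three bonds along the chain from such a carbon. Resting on a 1.0-fold higher number from compound 1 to compound 2 (0.01 log units; within the scatter) and a 1.0-fold higher number from compound 2 to compound 3 (0.01 log units; within the scatter), both within the scatter, compound 4 is expected to show a step of a 1.0-fold higher number from compound 3 to compound 4 (0.01 log units; within the scatter). Compound 4 is estimated at 1250000 nM, between 600000 nM and 2600000 nM.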

Compound 4, half-maximal inhibitory concentration: 1170000 nM
Compound 4: the middle estimate sits 1.1-fold (0.03 log units) above what was measured; low and high end bracket the measured number.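

In this assay, ethyl in place of hydrogen gives a 1.1-fold lower number from compound 3 to compound 4 (0.02 log units; within the scatter), so this change, made on a saturated chain carbon three bonds along the chain from a carbon with a double bond to nitrogen, leaves the number within the scatter. Set beside the earlier case, the same change reads alike on the two cores: the same change on two cores in this assay, a 1.0-fold higher number (0.01 log units; within the scatter) from compound 1 to compound 2 and a 1.1-fold lower number (0.02 log units; within the scatter) from compound 3 to compound 4, 1.1-fold (0.04 log units) apart, within the scatter of two such steps This shows that, in these two cases, the change carried over as a step within the scatter, but it rests on two cores only, the ethyl enters at a different place in each, and it does not show that the change would carry over in the same way on any other core.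

The compounds shown carry only saturated hydrocarbon chains on the carbon with a double bond to nitrogen, so it remains open whether a longer chain, an amine or a carboxylic acid there would give a step beyond the scatter. As far as these compounds go, whether changes elsewhere on the shared core, such as replacing the nitro group, would do so also remains open.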